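The source may report more compounds than this note shows. Statements on the series, on what has been measured and on what is new or still open speak of the compounds shown alone.

In an ADME assay on microsomes from liver (Mus musculus) for metabolic stability, read by LC-MS, using NADPH, with stated times of 15 min and 60 min, tested at 4.6 uM (a higher number here means that the compound lasts longer, a lower number that the compound disappears faster), compound 2 `CN1CCC(c2ccc3c(c2)oc(=O)n3C(=O)NCCOCc2ccccc2)CC1` gives 0.5 h. Compound 3 `CN1CCC(c2ccc3c(c2)oc(=O)n3C(=O)NCCCCc2ccccc2)CC1=O` gives 0.583 h in this assay, a gap to compound 2 that sits within the usual scatter. Compound 1 `CC(C)CNC(=O)n1c(=O)oc2cc(C3CCN(C)CC3)ccc21` reaches the limit of this assay at > 1 h, so no number is known for it. Compound 4 `CCCCCNC(=O)n1c(=O)oc2cc(C3CCN(C)CC3)ccc21` has not yet been run in this assay. It differs from compound 2 by propyl in place of benzyloxy on a saturated chain carbon, two bonds along the chain from an amide-type nitrogen. Within the data shown here, the one measured step that touches this part of the chain is an at least 2.0-fold lower number from compound 1 to compound 2 (0.30 log units; that floor lies within the scatter); its size is bounded only by the limit of > 1 h in this assay, at which 1 of the 3 values shown sits, so the true drop may be larger than the floor. Compound 4 reverses the direction of that step, removing the benzyloxy group and leaving a plain alkyl chain, so a rise in half-life in this assay is expected, of about a 1.8-fold higher number from compound 2 to compound 4 (0.26 log units; within the scatter). Compound 3, whose phenyl-bearing chain gives 0.583 h, does not settle how far an alkyl chain alone carries. For compound 4 the estimate in this assay is 0.9 h, within 0.45 h to 1.8 h, with a fair chance that only the limit is reported.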

Compound 4, half-life: > 1 h
Compound 4 ended at the assay's limit; the forecaster's own chance of this, stated with the estimate: 40%; at least 1.1-fold (0.04 log units) between middle value and limit.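

On these data alone, with propyl in place of benzyloxy at this place on the chain, this assay gives an at least 2.0-fold higher number from compound 2 to compound 4 (0.30 log units; that floor lies within the scatter), and the true size remains open beyond that floor. Compound 1 showed this direction with a branched isobutyl-type chain only; a straight pentyl chain in compound 4 now also reaches the limit, so both alkyl-chain compounds shown sit there, while compound 2 with its benzyloxy end keeps a readable number. The two alkyl chains cannot be ranked against each other, and the step between them cannot be read: the limit of > 1 h in this assay, at which 2 of the 4 values shown sit.

The compounds shown leave open whether the step follows the aromatic ring or the oxygen of the benzyloxy group, which a methoxy or cyclohexyloxy group at this place would separate. As far as these compounds go, how far any alkyl chain lies past the limit also stays open.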